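Swapping piperidine for piperazine on a cytotoxicity probe

This account rests on a few compounds, and the source may have more. Where it says the series, first, only, none or still open, it means among the compounds named here.

Compound 1, `Cc1ccc(-[n+]2noc([O-])c2CN2CCCCC2)cc1`, was tested in an ADME assay on HEL cells (Homo sapiens) for cytotoxicity (a lower number here means that less compound is tolerated, a higher number that more compound is tolerated), and gives 100 ug/mL. Compound 3, `[O-]c1on[n+](-c2ccc(Cc3ccc(-[n+]4noc([O-])c4CN4CCN(c5cccc(Cl)c5Cl)CC4)cc3)cc2)c1CN1CCN(c2cccc(Cl)c2Cl)CC1`, gives 100 ug/mL, so compound 1 stands level with compound 3 within the scatter. Compound 2, `[O-]c1c[n+](-c2ccc(Cc3ccc(-[n+]4cc([O-])on4)cc3)cc2)no1`, gives >= 20 ug/mL, and this value is a limit of the assay rather than a number. Compound 4, `Cc1ccc(-[n+]2noc([O-])c2CN2CCNCC2)cc1`, has not yet been measured. It differs from compound 1 in one place: piperazin-1-yl in place of piperidin-1-yl on a saturated chain carbon bound to an aromatic carbon. For the measured compounds named here, no measured pair shows the effect of this change, so no step beyond the scatter is expected, in either direction. Compound 4 is therefore expected to give 100 ug/mL, with a range from 50 ug/mL to 200 ug/mL, an estimated step of no change at the digits printed from compound 1 to compound 4 (within the scatter).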

Compound 4, minimum cytotoxic concentration: 100 ug/mL
Estimate against measurement, compound 4: no gap at the digits printed; measured number inside the range.
By their numbers in this assay, from the lowest: compounds 1, 3 and 4 (each within the scatter of the next).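

For the compounds shown here, the swap of piperidin-1-yl for piperazin-1-yl on a saturated chain carbon bound to an aromatic carbon gives the first one-place comparison in this assay, with no change at the digits printed from compound 1 to compound 4 (within the scatter). Within this single pair, the extra ring nitrogen and hydrogen-bond donor of piperazin-1-yl leave the cytotoxicity reading level with that of piperidin-1-yl. Nothing measured here gives a reason for this.

As far as these compounds go, whether morpholine or an open-chain dimethylamino group in the same place would read alike remains open. So does whether the same swap reads alike on a different core.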